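The compounds below may be only part of what the source reports. "The series", "measured", "known", "first", "only" and "open" are said of these compounds alone.

Among the compounds with values here, the three compounds measured so far share one core and differ only in the aryl group attached to it. In a functional assay on BJAB cells (Homo sapiens) for antiproliferative activity, with a stated time of 4 days (on this read-out higher numbers stand for an effect only at larger amounts of compound and lower numbers for an effect already at smaller amounts), compound 1 `COc1cc(-c2c(C)nn(-c3nc(-c4ccc(Cl)c(Cl)c4)c(SC(C)C)s3)c2C(=O)O)cc(C(F)(F)F)c1` gives 1380 nM, compound 2 `Cc1cc(C#N)cc(-c2c(C)nn(-c3nc(-c4ccc(Cl)c(Cl)c4)c(SC(C)C)s3)c2C(=O)O)c1` gives 4800 nM, and compound 3 `Cc1nn(-c2nc(-c3ccc(Cl)c(Cl)c3)c(SC(C)C)s2)c(C(=O)O)c1-c1ccccc1[N+](=O)[O-]` gives 4700 nM. Compound 3 thus stands second highest of the three numbers: the step of a 1.0-fold lower number from compound 2 to compound 3 (0.01 log units; within the scatter) lies within the scatter, whereas a 3.4-fold higher number from compound 1 to compound 3 (0.53 log units; beyond the scatter) is a modest step beyond it, much like a 3.5-fold higher number from compound 1 to compound 2 (0.54 log units; beyond the scatter).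

Compound 4 `CCOc1ncccc1-c1c(C)nn(-c2nc(-c3ccc(Cl)c(Cl)c3)c(SC(C)C)s2)c1C(=O)O` is the next to be measured in this assay. Its change from compound 3 is 2-ethoxypyridin-3-yl in place of 2-nitrophenyl on an aromatic carbon. Within the data shown here, no measured step touches a 2-ethoxypyridin-3-yl group, so the only guide is how far the aryl swaps seen so far moved this assay: a 3.5-fold higher number from compound 1 to compound 2 (0.54 log units; beyond the scatter) and a 3.4-fold higher number from compound 1 to compound 3 (0.53 log units; beyond the scatter) were modest, and a 1.0-fold lower number from compound 2 to compound 3 (0.01 log units; within the scatter) stayed within the scatter. A change of at most modest size in either direction is therefore expected, and compound 4 is expected to show a step of about a 1.6-fold lower number from compound 3 to compound 4 (0.19 log units; within the scatter). Compound 4 is estimated at 3000 nM in this assay, with a range from 1000 nM to 9000 nM.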

Compound 4, half-maximal effective concentration: 11000 nM
For compound 4 the middle estimate is 3.7-fold (0.56 log units) below the measured one; the whole stated range lies below it.
By their numbers in this assay, from the lowest: compound 1; then compounds 3 and 2 (each within the scatter of the next); then compound 4.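

In this assay, within the data shown here, 2-ethoxypyridin-3-yl is the first group at this position to separate from the pair of compound 2 and compound 3, which lay within the scatter of each other, with a 2.3-fold higher number from compound 3 to compound 4 (0.37 log units; beyond the scatter) and a 2.3-fold higher number from compound 2 to compound 4 (0.36 log units; beyond the scatter). Among these compounds, with an 8.0-fold higher number from compound 1 to compound 4 (0.90 log units; beyond the scatter), compound 4 has the highest number of the four, and the spread across this aromatic carbon, which bears the aryl group, is wider than the earlier steps showed, though every step remains modest. The step from compound 3 to compound 4 also came with no change in the count of heavy atoms or hydrogen-bond acceptors, and no measurement at hand accounts for it.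

The compounds shown leave open whether the step goes with the ring nitrogen or with the ethoxy chain, as none of them carries one without the other. A phenyl group bearing the ethoxy chain and a pyridine ring without it would separate the two, while an amine or a longer alkoxy chain on the aryl ring remains an open case at this position.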